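The compounds below may be only part of what the source reports. "The series", "measured", "known", "first", "only" and "open" are said of these compounds alone.

Compound 3 `COc1ccc(Cl)cc1N(CC(=O)NC1CCCCC1)S(=O)(=O)c1ccccc1` carries a cyclohexyl group on the amide-type nitrogen of the shared core. In a functional assay on SH-SY5Y cells (Homo sapiens), read by MTT assay, with a stated time of 24 h (on this read-out lower numbers stand for an effect already at smaller amounts and higher numbers for an effect only at larger amounts of compound), compound 3 gives 17600 nM, the highest of the two numbers recorded; its nearest neighbour is compound 1 `COc1ccc(Cl)cc1N(CC(=O)Nc1ccc(C(F)(F)F)cc1)S(=O)(=O)c1ccccc1`, which in this assay gives 3750 nM. Compound 2 `COc1ccc(Cl)cc1NC(=O)CN(c1cc(Cl)ccc1OC)S(=O)(=O)c1ccccc1` is reported only as a limit of this assay, > 20000 nM. The step of a 4.7-fold higher number from compound 1 to compound 3 (0.67 log units; beyond the scatter) shows that replacing the aryl group with cyclohexyl raised the number; the step of an at least 5.3-fold higher number from compound 1 to compound 2 (0.72 log units; beyond the scatter) shows that a second aryl group did not do as well as the first, while an at least 1.1-fold lower number from compound 2 to compound 3 (0.05 log units; that floor lies within the scatter) cannot separate cyclohexyl from that second aryl group.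

Compound 4 `COc1ccc(Cl)cc1N(CC(=O)Nc1ccc([N+](=O)[O-])cc1)S(=O)(=O)c1ccccc1` differs from compound 3 by 4-nitrophenyl in place of cyclohexyl on an amide-type nitrogen. This reverses the direction of the cyclohexyl step and returns to an aryl group on the amide-type nitrogen, so a lower number is expected for compound 4 in this assay, of a size like a 3.5-fold lower number from compound 3 to compound 4 (0.55 log units; beyond the scatter). Compound 4 is therefore estimated at 5000 nM, within the range 2000 nM to 15000 nM.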

Compound 4, half-maximal effective concentration: 8210 nM
Estimate against measurement, compound 4: 1.6-fold (0.22 log units) below, and the stated range covers the measured number.
By their numbers in this assay, from the lowest: compound 1; then compound 4; then compound 3. At a limit, above all of these: compound 2.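

In this assay, the step of a 2.1-fold lower number from compound 3 to compound 4 (0.33 log units; beyond the scatter) shows that the lower number with an aryl group on the amide-type nitrogen is not confined to 4-(trifluoromethyl)phenyl. Among these compounds, the step of a 2.2-fold higher number from compound 1 to compound 4 (0.34 log units; beyond the scatter) adds the first comparison of two substituents on that aromatic ring, and shows that the choice of substituent itself moves the number, with nitro giving the higher one. The step of an at least 2.4-fold lower number from compound 2 to compound 4 (0.38 log units; beyond the scatter) separates 4-nitrophenyl from 5-chloro-2-methoxyphenyl, which cyclohexyl could not do, but it is only a floor, because compound 2 stands at a limit of the assay: the limit of > 20000 nM in this assay, at which 1 of the 4 values shown sits.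

From the compounds shown here alone, whether an unsubstituted phenyl, a 4-methoxyphenyl or a 4-aminophenyl group on this nitrogen would give a number like those of the aryl compounds stays open. So does whether a benzyl group or a shorter alkyl chain would behave like cyclohexyl.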